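A Pyridine Ring Swap on a Trifluoromethyl Ketone Thiophene Series

A few compounds are considered here, and "the series" means these few. Any claim that something is new, unique, unknown or untested is made for them only; others in the source may bear on it.

Measured compounds:
Compound 1, `O=C(c1ccc(-c2nc(-c3cccnc3)no2)s1)C(F)(F)F`: 70 nM
Compound 2, `O=C(c1ccc(-c2nc(CS(=O)(=O)c3cccs3)no2)s1)C(F)(F)F`: 35 nM

Both compounds were tested in an assay for inhibition of histone deacetylase 4 (Homo sapiens); on this read-out higher numbers stand for weaker inhibition and lower numbers for stronger inhibition. Compound 1 gives 70 nM, which stands at the high end of the two numbers, but its gap to compound 2, which gives 35 nM, stays within the usual scatter, so the two cannot be told apart on this assay. Among the compounds with values here, no step between two measured compounds that differ in one place is available.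

Compound 3, `O=C(c1ccc(-c2nc(-c3ccccn3)no2)s1)C(F)(F)F`, has not yet been measured in this assay. It differs from compound 1 by pyridin-2-yl in place of pyridin-3-yl on an aromatic carbon. Within the data shown here, nothing among the measured compounds shows what such a change does, so the step from compound 1 to compound 3 is expected to stay small, in no clear direction, and estimated as a 1.1-fold higher number from compound 1 to compound 3 (0.06 log units; within the scatter). For compound 3 the expected value in this assay is 80 nM, with a range from 30 nM to 220 nM.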

Compound 3, half-maximal inhibitory concentration: 90 nM
Compound 3: the middle estimate sits 1.1-fold (0.05 log units) below what was measured; the range from low to high includes it.
By their numbers in this assay, from the lowest: compounds 2, 1 and 3 (each within the scatter of the next, the first and the last beyond it).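

In this assay, pyridin-2-yl in place of pyridin-3-yl, on the aromatic carbon between two ring nitrogen atoms, gives a 1.3-fold higher number from compound 1 to compound 3 (0.11 log units; within the scatter) and leaves compound 1 and compound 3 indistinguishable. Within the data shown here, this is the first single-place comparison, and it shows that, at this position and on this read-out, this change of pyridine attachment has no effect that can be separated from the scatter. No measurement here offers any explanation of this result.

The compounds shown leave open whether pyridin-4-yl, a plain phenyl ring, or a pyridine ring carrying an amine or a carboxylic acid would also stay within the scatter of compound 1 at this carbon. They also do not show how the thiophene-2-sulfonylmethyl group of compound 2 relates to either pyridine, since that compound differs from them in more than one place.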